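The compounds below may be only part of what the source reports. "The series", "measured", "known", "first", "only" and "open" are said of these compounds alone.

Measured compounds:
Compound 1, `c1ccc(COc2cccc(-c3cn([C@@H]4CN5CCC4CC5)nn3)c2)cc1`: 6.67 nM
Compound 2, `Fc1cccc(-c2cn(C3CN4CCC3CC4)nn2)c1`: 5.24 nM
Compound 3, `Fc1ccc(COc2cccc(-c3cn(C4CN5CCC4CC5)nn3)c2)cc1`: 13.9 nM

In an assay on HEK293 cells for displacement of a labelled ligand from Neuronal acetylcholine receptor; alpha3/beta4 (Homo sapiens), read by scintillation counting, with a stated time of 120 min (a higher number here means a weaker inhibitor, a lower number a stronger inhibitor), compound 3 gives the highest of the three numbers, so it is the weakest inhibitor of the set. Compound 4, `c1ccc(COc2cccc(-c3cn(C4CN5CCC4CC5)nn3)c2)cc1`, differs from compound 3 by hydrogen in place of fluoro on an aromatic carbon. For the measured compounds named here, the only step measured, a 2.7-fold higher number from compound 2 to compound 3 (0.42 log units; beyond the scatter), concerns a different change and does not bear on this one. Compound 1 carries the same benzyloxy group as compound 4, and in this assay compound 1 gives 6.67 nM, whereas compound 3 gives 13.9 nM. The step is therefore expected to bring a lower number, a 2.0-fold lower number from compound 3 to compound 4 (0.30 log units; within the scatter), with compound 4 estimated at 7 nM, within a range from 3.5 nM to 15 nM.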

Compound 4, inhibition constant: 7.57 nM
The estimate for compound 4 lay 1.1-fold (0.03 log units) below the measured number; measured number inside the range.
By their numbers in this assay, from the lowest: compounds 2, 1, 4 and 3 (each within the scatter of the next, the first and the last beyond it).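

In this assay, hydrogen in place of fluoro on the aromatic carbon para to a large group gives a 1.8-fold lower number from compound 3 to compound 4 (0.26 log units; within the scatter) and so stays within the scatter at this place. Benzyloxy in place of fluoro gives a 1.4-fold higher number from compound 2 to compound 4 (0.16 log units; within the scatter) and also stays within it, whereas the step to the (4-fluorobenzyl)oxy compound 3 lay beyond it. The pair with a 1.1-fold higher number from compound 1 to compound 4 (0.05 log units; within the scatter) shows no separation either, yet it cannot settle what the configuration contributes: the fact that one of compounds 1 and 4 is drawn with a defined configuration and the other without, at the place where they differ.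

As far as these compounds go, whether chloro or methoxy at this same place would read differently stays open, as does the reading of the R form of compound 1.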